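A few compounds are considered here, and "the series" means these few. Any claim that something is new, unique, unknown or untested is made for them only; others in the source may bear on it.

The measured compounds:
Compound 1, `Cc1cc(-n2cc(C(=O)Nc3cc(F)cc(F)c3)c(=O)c3ccc(N(C)C)nc32)ccc1OCCCCCCC[N+]1(C)CCCC1`, gives 26.1% in an assay on LX2 cells for inhibition of COL1A1 promoter (Homo sapiens), read by a luciferase reporter, with a stated time of 24 h, tested at 20 uM; on this read-out lower numbers stand for a weaker effect and higher numbers for a stronger effect at the one concentration tested.
Compound 2, `Cc1ccc(-n2cc(C(=O)Nc3cc(F)cc(F)c3)c(=O)c3ccc(N(C)C)nc32)cc1OCCCCCCC[N+]1(C)CCCC1`, gives 12.7% in this assay.
Compound 3, `Cc1cc(-n2cc(C(=O)Nc3cc(F)cc(F)c3)c(=O)c3ccc(N(C)C)nc32)ccc1OCCCCCCC[n+]1ccccc1`, gives "not active" (no number reported) in this assay, with no number given.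

Compound 3 therefore stands at the low end of what is known: where compound 1 and compound 2 each have a number, compound 3 has only the word not active. Compound 4, `CC[N+]1(CCCCCCCOc2ccc(-n3cc(C(=O)Nc4cc(F)cc(F)c4)c(=O)c4ccc(N(C)C)nc43)cc2C)CCCC1`, differs from compound 3 in a single place: a group of 7 heavy atoms (6 carbon, 1 nitrogen; one five-membered non-aromatic ring with 1 hetero atom) in place of a group of 6 heavy atoms (5 carbon, 1 nitrogen; one six-membered aromatic ring with 1 hetero atom), on a saturated chain carbon, seven bonds along the chain from an oxygen on an aromatic ring. Within the data shown here, the entering group is of the same kind as the one carried by compound 1, a five-membered non-aromatic ring with one hetero atom, here with one more carbon on it. Among the measured compounds shown here, no measured pair shows this exact change directly, so its size cannot be read off. Still, a step upward from compound 3 beyond the usual scatter is expected, since compound 1 with the related ring gives 26.1% in this assay. For compound 4 the expected value in this assay is 22%, in a range from 5% to 40%.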

Compound 4, a percentage reported as inhibition, at one concentration (the size of the read-out at that concentration, not a potency): 44.7%
Compound 4: the middle estimate sits 22.7 percentage points below what was measured; measured number outside the range, above it.
By their numbers in this assay, from the lowest: compound 2; then compound 1; then compound 4.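

The group at the end of the chain responds to a very small edit: in this assay, a methyl in place of hydrogen on a saturated chain carbon bound to an amine nitrogen in a ring brings a number 18.6 percentage points higher from compound 1 to compound 4 (beyond the scatter). So the read-out here depends not only on the kind of ring at the end of the chain but also on what the ring nitrogen carries, although compound 3 has no number, so no step to or from it can be read. Nothing available explains why this added methyl raises the number.

On these data alone, whether a propyl or a benzyl group on the same ring nitrogen would raise the number further remains open. So does whether a piperidine ring in place of the five-membered ring would keep the gain, and these single-concentration values say nothing about potency.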